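Swapping a guanidine for an amide chain on the shared core

A few compounds are considered here, and "the series" means these few. Any claim that something is new, unique, unknown or untested is made for them only; others in the source may bear on it.

Compound 1, `COc1ccc(-c2nc(N=C(N)N)sc2-c2ccc(OC)cc2)cc1`: in a functional assay with Oryctolagus cuniculus as the target (a higher number here means a weaker inhibitor, a lower number a stronger inhibitor), compound 1 gives 31000 nM.
Compound 2, `COc1ccc(-c2nc(/N=C(\N)NC(C)C)sc2-c2ccc(OC)cc2)cc1`: in this assay compound 2 gives > 100 nM, which is a limit of the assay and not a number.
Compound 3, `COc1ccc(-c2nc(CN)sc2-c2ccc(OC)cc2)cc1`: in this assay compound 3 gives > 100 nM, again a limit of the assay rather than a number.

Within the data shown here, compound 1 is therefore the only compound with a real number in this assay; the other two values only mark a limit, and on that footing compound 1 is a weak inhibitor. Compound 4, `COc1ccc(-c2nc(CNC(=O)CSC)sc2-c2ccc(OC)cc2)cc1`, is built from compound 1 by one change: a group of 7 heavy atoms (4 carbon, 1 nitrogen, 1 oxygen, 1 sulfur; no ring) in place of a group of 4 heavy atoms (1 carbon, 3 nitrogen; no ring), on an aromatic carbon. Among the measured compounds shown here, two measured steps touch the same carbon of the shared core: a step that the limit leaves unreadable from compound 1 to compound 2 and a step that the limit leaves unreadable from compound 1 to compound 3. Neither has a readable size, and the same holds for a step that the two limits leave unreadable from compound 2 to compound 3. All that the measurements show is the limit of > 100 nM in this assay, at which 2 of the 3 values shown sit, so no direction can be read for the step to compound 4 beyond the expectation that it stays weak. Compound 4 is estimated at 30000 nM, with a range from 5000 nM to 150000 nM. This estimate means a step of a 1.0-fold lower number from compound 1 to compound 4 (0.01 log units; within the scatter) that is expected to lie within the scatter, with a fair chance that only a limit is reported.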

Compound 4, half-maximal inhibitory concentration: < 100 nM
Compound 4: a limit, no number (the forecaster's own chance of this, stated with the estimate: 55%); middle value at least 300-fold (2.47 log units) from the limit.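

Among these compounds, on the aromatic carbon next to the ring nitrogen and next to the ring sulfur, putting ((((methylsulfanyl)methyl)carbonyl)amino)methyl in place of the guanidine of compound 1 gives an at least 310-fold lower number from compound 1 to compound 4 (2.49 log units; beyond the scatter) in this assay, the first step at this position with a readable size. Compound 4 gives < 100 nM and this is a limit of the assay and not a number. The step of a number no higher from compound 2 to compound 4 (the limit leaves the size open) and the step of a number no higher from compound 3 to compound 4 (the limit leaves the size open) cannot be read, so the clear separation holds only between compound 1 and compound 4.

The compounds shown leave open whether the methylsulfanyl end of the chain matters, a question that a plain acetyl group or a methoxyacetyl group on the same amine nitrogen would address. They also leave open how low the number for compound 4 really lies, and how a longer chain on the same carbon would compare.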